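A Fluorophenyl for a Thiophene on the Sulfonamide

The compounds below may be only part of what the source reports. "The series", "measured", "known", "first", "only" and "open" are said of these compounds alone.

Three sulfonamides have been tested in an assay on cells for inhibition of HSP60/HSP10 (Homo sapiens), with a stated time of 60 min; on this read-out lower numbers stand for stronger inhibition and higher numbers for weaker inhibition. Compound 1 (`O=S(=O)(Nc1ccc(-c2nc3ccccc3o2)cc1)c1ccccc1O`) gives only a limit, > 100000 nM, in this assay. That limit is recorded as the limit of > 100000 nM in this assay, at which 1 of the 3 values shown sits. Compound 2 (`O=S(=O)(Nc1ccc2oc(-c3ccccc3)nc2c1)c1cccs1`) gives 90000 nM in this assay, and compound 3 (`O=S(=O)(Nc1ccc(-c2nc3ccccc3o2)cc1)c1ccc(C(F)(F)F)cc1`) gives 50000 nM; these two numbers sit within the scatter of each other, so neither can be called weaker or stronger than the other. For the measured compounds named here, no pair among the measured compounds differs in a single place, so no measured step is available to lean on.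

Compound 4 (`O=S(=O)(Nc1ccc2oc(-c3ccccc3)nc2c1)c1ccccc1F`) has not yet been measured in this assay. It differs from compound 2 in one place: 2-fluorophenyl in place of thiophen-2-yl on a sulfonyl sulfur. Going by the values given here, with no measured step of this kind to guide the expectation, and with every number so far lying in the same weak region, the author expects no step beyond the scatter from compound 2 to compound 4, that is a 1.1-fold lower number from compound 2 to compound 4 (0.05 log units; within the scatter). Compound 4 is accordingly estimated at 80000 nM in this assay, with a range from 30000 nM to 200000 nM.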

Compound 4, half-maximal inhibitory concentration: > 100000 nM
Compound 4 ended at the assay's limit (the forecaster's own chance of this, stated with the estimate: 35%); middle value at least 1.2-fold (0.09 log units) away from the limit.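

In this assay compound 4 gives > 100000 nM, which is a limit of the assay and not a number. For the compounds shown here, this is the first measured step at this position, on a sulfonyl sulfur: putting 2-fluorophenyl in place of thiophen-2-yl gives an at least 1.1-fold higher number from compound 2 to compound 4 (0.04 log units; that floor lies within the scatter), so the change brought no lower number, though only a floor for the step is known. The true size of the step stays unknown because the read-out ends at a limit: the limit of > 100000 nM in this assay, at which 2 of the 4 values shown sit.

Going by these compounds, whether the swap of the ring or the fluorine itself matters remains open, and a plain phenyl on the sulfonyl sulfur would separate the two. Also open, on these data alone, is whether a phenyl bearing an amine or a carboxylic acid at this position would bring the number clearly down from this weak region.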